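Oxime Ether Variant of a Diaryl Thioether Oxime

A few compounds are considered here, and "the series" means these few. Any claim that something is new, unique, unknown or untested is made for them only; others in the source may bear on it.

Compound 2, `CC(C)/C(=N\O)c1ccc(Sc2cc(F)cc(C3CCOCC3)c2)cc1`, gives 300 nM in a functional assay (blood) for inhibition, with Homo sapiens as the target; a lower number here means a stronger inhibitor, a higher number a weaker inhibitor.
Compound 3, `CO[C@]1(c2cnc(S(=O)(=O)c3ccc(/C(C)=N/O)cc3)s2)CCO[C@@H](C)C1`, gives 320 nM in this assay.
Compound 1, `C/C(=N\O)c1ccccc1Sc1cc(F)cc(C2CCOCC2)c1`, sits at > 10000 nM in this assay, which is a limit of the assay and not a number.

Compound 2 has the lowest of the two numbers shown, but compound 3 lies so close that the two fall within the usual scatter of this assay, so no order between them can be read. For compound 1 only a limit is known (the limit of > 10000 nM in this assay, at which 1 of the 3 values shown sits), so it cannot be placed against the others.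

Compound 4, `C/C(=N\OCC#N)c1ccc(Sc2cc(F)cc(C3CCOCC3)c2)cc1`, has not been measured yet. Compared with compound 2 it carries a different group on the same aromatic carbon: a group of 7 heavy atoms (4 carbon, 2 nitrogen, 1 oxygen; no ring) in place of a group of 6 heavy atoms (4 carbon, 1 nitrogen, 1 oxygen; no ring), on an aromatic carbon.

Among the compounds with values here, no pair of measured compounds differs in just one place, so there is no measured step to set the size of this change. The two groups are of similar size and the rest of the shared core is untouched, so the expectation in this assay is a step of modest size, if any, most likely a slight weakening. Compound 4 is therefore estimated at 500 nM, with a range from 120 nM to 2500 nM. This estimate corresponds to a step of a 1.7-fold higher number from compound 2 to compound 4 (0.22 log units; within the scatter).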

Compound 4, half-maximal inhibitory concentration: 20 nM
For compound 4 the middle estimate is 25-fold (1.40 log units) above the measured one; measured number outside the range, below it.
By their numbers in this assay, from the lowest: compound 4; then compounds 2 and 3 (each within the scatter of the next). At a limit, above all of these: compound 1.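

This position, an aromatic carbon para to a large group, proves highly sensitive: exchanging one group for another of nearly the same size gives a 15-fold lower number from compound 2 to compound 4 (1.18 log units; beyond the scatter) in this assay. Heavy-atom count alone therefore does not set the number at this position. The entering group has 0 hydrogen-bond donors where the leaving group has 1, so a low number here does not require a hydrogen-bond donor in this group, although nothing measured accounts for the size of the step.

Going by these compounds, the change alters several features at once, so it remains open which of them carries the step: an oxime with its free hydroxyl and a methyl on the carbon, or one with a plain methyl on the oxygen, would help separate them. On these data alone, it is also open whether the nitrile itself matters, a question that a longer chain ending in a nitrile, or a chain of similar length ending in an amine or a carboxylic acid, could address.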